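Shrinking a Ring Substituent: Expected Cytotoxicity of Compound 4

This account rests on a few compounds, and the source may have more. Where it says the series, first, only, none or still open, it means among the compounds named here.

Three compounds have been measured in an ADME assay on MDCK cells (Canis lupus familiaris) for cytotoxicity, read by microscopy, with a stated time of 48 h; on this read-out lower numbers stand for higher toxicity in this test and higher numbers for lower toxicity in this test:

Compound 1 `CCc1ccc(CN[C@@H]2C[C@H]3C[C@@H]([C@H]2C)C3(C)C)s1` gives 1560 nM
Compound 2 `C[C@H]1[C@H](NCc2ccc(Br)s2)C[C@H]2C[C@@H]1C2(C)C` gives 43000 nM
Compound 3 `C[C@H]1[C@H](NCc2sccc2C2CCCCC2)C[C@H]2C[C@@H]1C2(C)C` gives 1560 nM

Compound 3 stands level with compound 1 at the digits shown, and these two share the lowest number of the three; compound 2 is the highest. Going by the values given here, the only single-place step measured is a 28-fold higher number from compound 1 to compound 2 (1.44 log units; beyond the scatter), a large one, but it concerns bromo in place of ethyl and says nothing about the change now at hand.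

Compound 4 `C[C@H]1[C@H](NCc2sccc2C2CCCC2)C[C@H]2C[C@@H]1C2(C)C` differs from compound 3 by cyclopentyl in place of cyclohexyl on an aromatic carbon. Among the compounds with values here, no measured step bears on this change, so a step of no more than the usual scatter is expected in this assay. Compound 4 is therefore estimated at 1560 nM, between 700 nM and 4000 nM. This estimate means an expected step of no change at the digits printed from compound 3 to compound 4 (within the scatter).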

Compound 4, minimum cytotoxic concentration: 12500 nM
For compound 4 the middle estimate is 8.0-fold (0.90 log units) below the measured one, and the stated range ends below it.
By their numbers in this assay, from the lowest: compounds 1 and 3 (each within the scatter of the next); then compound 4; then compound 2.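

In this assay, compound 4 shows that ring size at this position matters: with cyclopentyl in place of cyclohexyl on this aromatic carbon, the result is an 8.0-fold higher number from compound 3 to compound 4 (0.90 log units; beyond the scatter). Even a small change within a saturated carbon ring can therefore move this read-out beyond the scatter, which the earlier bromo-for-ethyl step could not show. Nothing measured here accounts for this step. The compounds shown leave open whether a smaller ring such as cyclobutyl would give a still higher number. On these data alone, how an open chain such as isopropyl, or a ring carrying an amine, would behave at this position also remains open.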